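The source may report more compounds than this note shows. Statements on the series, on what has been measured and on what is new or still open speak of the compounds shown alone.

Three compounds built on a shared core carrying a nitrile-bearing chain have been tested in a functional assay on NCI-H226 cells (Homo sapiens) for cytotoxicity, read by sulforhodamine B assay, with a stated time of 48 h, tested at 0.001 uM; on this read-out lower numbers stand for a stronger effect and higher numbers for a weaker effect at the one concentration tested. Compound 1 `COc1cc(C)cc(-c2c(-c3ccnc(-c4ccc(C(C)=O)cc4)c3)cnn2CC#N)c1` gives 100%, compound 2 `COc1cc(C)cc(-c2nn(CC#N)cc2-c2ccc(-c3cccc(C(C)=O)c3)nc2)c1` gives 95%, and compound 3 `Cc1cc(O)cc(-c2nn(CC#N)cc2-c2ccnc(-c3ccc(Oc4ccccc4)cc3)c2)c1` gives 92%. Compound 3 has the lowest of the three numbers, yet its gaps to compound 2 and to compound 1 both lie within the scatter, so the three cannot be told apart. Compound 4 `Cc1cc(O)cc(-c2nn(CC#N)cc2-c2ccnc(-c3ccc(N(C)C)cc3)c2)c1` has not yet been measured; it differs from compound 3 in one place: dimethylamino in place of phenoxy on an aromatic carbon. Among the measured compounds shown here, no measured pair shows this change, so nothing here tells how it acts. Because compound 3 gives 92%, compound 4 is expected to behave alike, with an estimated step of a number 2 percentage points higher from compound 3 to compound 4 (within the scatter) not beyond the scatter. The expected value for compound 4 is 94%, between 82% and 106%.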

Compound 4, a percentage reported as activity, at one concentration (the size of the read-out at that concentration, not a potency): 100%
The estimate for compound 4 lay 6 percentage points below the measured number; the measured number falls inside the stated range.
By their numbers in this assay, from the lowest: compounds 3, 2, 1 and 4 (each within the scatter of the next).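

In this assay, among the compounds shown here, placing dimethylamino instead of phenoxy on the aromatic carbon para to a large group gives a number 8 percentage points higher from compound 3 to compound 4 (within the scatter) and so gives the first direct look at a change at this position. Within the scatter, a group with one six-membered aromatic ring and 7 heavy atoms cannot be told apart from a ringless group with 3 heavy atoms at this one concentration. No supporting measurement explains this result. From the compounds shown here alone, whether a carboxylic acid or a longer chain at this position would separate from compound 3 stays open. Also open, going by these compounds, is whether compound 3 and compound 4 would differ at higher concentrations.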